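Replacing pyrazin-2-yl with pyridin-3-yl on a urea

A few compounds are considered here, and "the series" means these few. Any claim that something is new, unique, unknown or untested is made for them only; others in the source may bear on it.

Values in a physicochemical assay for solubility, read by nephelometry, in phosphate buffer, measured as kinetic solubility, at pH 6.5 (on this read-out higher numbers stand for higher solubility and lower numbers for lower solubility), so far
Compound 1 `O=C(Nc1cccc(C(=O)O)c1)Nc1ccc(F)c(C(F)(F)F)c1` gives 12.5 ug/mL as a number
Compound 2 `O=C(Nc1ccc(F)c(C(F)(F)F)c1)Nc1cnccn1` gives < 1.6 ug/mL as a limit

Compound 2 therefore has no number in this assay and is known only by its limit. Compound 3 `O=C(Nc1cccnc1)Nc1ccc(F)c(C(F)(F)F)c1` differs from compound 2 by pyridin-3-yl in place of pyrazin-2-yl on an amide-type nitrogen on an amide-type nitrogen. Among the measured compounds shown here, no measured step between the compounds shows what this change does, so only a modest upward move is expected, an estimated at least 1.8-fold higher number from compound 2 to compound 3 (0.27 log units; that floor lies within the scatter) in this assay at best. For compound 3 the expected value is 3 ug/mL in this assay with an estimated range from 1.6 ug/mL to 10 ug/mL in the same read-out.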

Compound 3, solubility: 12.5 ug/mL
Estimate against measurement, compound 3: 4.2-fold (0.62 log units) below; the measured number lies above the stated range.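

In this assay, among the compounds shown here, pyridin-3-yl in place of pyrazin-2-yl on the amide-type nitrogen gives an at least 7.8-fold higher number from compound 2 to compound 3 (0.89 log units; beyond the scatter), the only step read at this position so far. The swap of one aromatic ring for another, with the heavy-atom count unchanged, is thus enough to produce a step beyond the scatter. Its full size remains unknown, since compound 2 is known only by a limit: the limit of < 1.6 ug/mL in this assay, at which 1 of the 3 values shown sits.

As far as these compounds go, whether an unsubstituted phenyl on the same nitrogen would read higher or lower than pyridin-3-yl stays open. So does the effect of adding an amine to the pyridin-3-yl ring.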